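Swapping Hydroxy for Cyano: What to Expect for Compound 4

A few compounds are considered here, and "the series" means these few. Any claim that something is new, unique, unknown or untested is made for them only; others in the source may bear on it.

Three compounds sharing one core have so far been run through an ADME assay on J774 cells (Mus musculus) for cytotoxicity, read by MTT assay, with a stated time of 48 h, tested at 50 ug/mL; on this read-out higher numbers stand for a weaker effect at the one concentration tested and lower numbers for a stronger effect. Compound 1 `O=C(N/N=C/c1ccc(Cl)cc1)c1cnccn1` gives 83%, compound 2 `O=C(N/N=C/c1ccc(F)cc1)c1cnccn1` gives 78%, and compound 3 `O=C(N/N=C/c1ccc(O)cc1)c1cnccn1` gives 100%. Compound 3 stands highest of the three: the step of a number 17 percentage points higher from compound 1 to compound 3 (beyond the scatter) and the step of a number 22 percentage points higher from compound 2 to compound 3 (beyond the scatter) both lie beyond the scatter, while the step of a number 5 percentage points lower from compound 1 to compound 2 (within the scatter) does not, so the two halogen compounds cannot be told apart.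

Compound 4 `N#Cc1ccc(/C=N/NC(=O)c2cnccn2)cc1` is the next candidate, and it differs from compound 3 in one place: cyano in place of hydroxy on an aromatic carbon

Among the compounds with values here, the steps that bear on this are the two that put hydroxy in place of a halogen, since each of them removed or added the same hydroxy group at the same position and each moved the number by a modest amount. Within the data shown here, no measured compound carries a cyano group, so the size of its own contribution is unknown. Removing the hydroxy is therefore expected to pull the number back toward the level of compounds 1 and 2, a modest step downward for compound 4 of a number 18 percentage points lower from compound 3 to compound 4 (beyond the scatter). Compound 4 is thus estimated at 82%, within a range from 65% to 100%.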

Compound 4, a percentage reported as activity, at one concentration (the size of the read-out at that concentration, not a potency): 100%
For compound 4 the middle estimate is 18 percentage points below the measured one; measured number inside the range.
By their numbers in this assay, from the lowest: compounds 2 and 1 (each within the scatter of the next); then compounds 3 and 4 (each within the scatter of the next).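

In this assay, within the data shown here, hydroxy is not the only group at this place on the aromatic ring that goes with a high number: replacing it with cyano gives no change at the digits printed from compound 3 to compound 4 (within the scatter), even though cyano has no hydrogen-bond donor and hydroxy has one. Compared with the halogens, cyano matches hydroxy, giving a number 22 percentage points higher from compound 2 to compound 4 (beyond the scatter) and a number 17 percentage points higher from compound 1 to compound 4 (beyond the scatter), so among these four compounds the two with a halogen form one group and the two without form another, with no compound going against this split. No measurement shown here explains why hydroxy and cyano match or why the halogen compounds differ from them.

Two groups without a halogen are too few to show what the upper group has in common, so an amine, a carboxylic acid or a methoxy group at the same place could land with either pair. A bromine atom there would test whether the lower numbers extend to a third halogen, and since each compound was tested at only one concentration, these numbers give no potency.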